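The source may report more compounds than this note shows. Statements on the series, on what has been measured and on what is new or still open speak of the compounds shown alone.

Series notes. Compound 1 `COc1cc2c(cc1C(C)NCc1ccccc1)CCC(C)(C)O2` in an ADME assay on L6 cells (Rattus norvegicus) for cytotoxicity (a higher number here means a weaker inhibitor, a lower number a stronger inhibitor), gives 15300 nM. Compound 2 `COc1cc2c(cc1C(C)NCCCc1ccccc1)CCC(C)(C)O2` in this assay gives 2630 nM. Within the data shown here, the one change between them, (phenethyl in place of phenyl on a saturated chain carbon bound to an amine nitrogen), produced a 5.8-fold lower number from compound 1 to compound 2 (0.76 log units; beyond the scatter). Compound 3 `CC(NCc1ccccc1)c1cc2c(cc1O)OC(C)(C)C=C2` in this assay gives 109000 nM, the highest of the three numbers; how its core differs from that of compound 1 is not broken down here. Compound 4 `CC(NCCCc1ccccc1)c1cc2c(cc1O)OC(C)(C)C=C2` is not yet measured and differs from compound 3 by phenethyl in place of phenyl on a saturated chain carbon bound to an amine nitrogen, at the same place as the earlier change and therefore the same change. Because the earlier instance gave a 5.8-fold lower number from compound 1 to compound 2 (0.76 log units; beyond the scatter), a step of about the same size is expected here, a 5.7-fold lower number from compound 3 to compound 4 (0.76 log units; beyond the scatter), though it rests on that single precedent. Compound 4 is accordingly estimated at 19000 nM, with the expected range running from 7000 nM to 55000 nM.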

Compound 4, half-maximal inhibitory concentration: 27000 nM
Compound 4: the middle estimate sits 1.4-fold (0.15 log units) below what was measured; low and high end bracket the measured number.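

Phenethyl in place of phenyl on a saturated chain carbon bound to an amine nitrogen again gives a lower number in this assay, with a 4.0-fold lower number from compound 3 to compound 4 (0.61 log units; beyond the scatter). The step carries from one core to the other with no difference in size that can be told apart: the same change on two cores in this assay, a 5.8-fold lower number (0.76 log units; beyond the scatter) from compound 1 to compound 2 and a 4.0-fold lower number (0.61 log units; beyond the scatter) from compound 3 to compound 4, 1.4-fold (0.16 log units) apart, within the scatter of two such steps. This supports transfer between these two cores in this one assay only; two pairs do not show that the step would hold on any other core, and they do not show what produces it.

Still open, going by these compounds, is how a longer chain, or a chain ending in an amine or a carboxylic acid, would behave in the same place. Also open, on these data alone, is which feature of the two cores sets the gap between compound 1 and compound 3.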